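The source may report more compounds than this note shows. Statements on the series, on what has been measured and on what is new or still open speak of the compounds shown alone.

Measured so far in a functional assay on Ehrlich cells (Mus musculus) for cytotoxicity, tested at 10 ug/mL; a higher number here means a stronger effect of the compound at the concentration tested, a lower number a weaker effect:
- compound 1 `COc1cc(N2C(N)=C(C#N)C(c3c(OC)ccc4ccccc34)C3=C2CC(C)(C)CC3=O)cc(OC)c1OC` gives 0%
- compound 2 `COc1cc(N2C(N)=C(C#N)C(c3c(O)ccc4ccccc34)C3=C2CC(C)(C)CC3=O)cc(OC)c1OC` gives 2%
- compound 3 `COc1cc(N2C(N)=C(C#N)C(c3ccc(C)cc3)C3=C2CC(C)(C)CC3=O)cc(OC)c1OC` gives 30%

All three compounds share one core and differ only in the group carried on a saturated ring carbon. Compound 3 stands highest of the three in this assay: the gap to the nearest of the others is a number 28 percentage points higher from compound 2 to compound 3 (beyond the scatter), and the gap to the furthest is a number 30 percentage points higher from compound 1 to compound 3 (beyond the scatter). By contrast, the step of a number 2 percentage points higher from compound 1 to compound 2 (within the scatter) shows that exchanging methyl for hydrogen on an oxygen of the naphthalene ring changes nothing.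

Compound 4 `COc1cc(N2C(N)=C(C#N)C(c3cccs3)C3=C2CC(C)(C)CC3=O)cc(OC)c1OC` is the next case. Its change from compound 3 is thiophen-2-yl in place of 4-methylphenyl on a saturated ring carbon.

Among the measured compounds shown here, the steps that bear on this position are the two just named, in which a 4-methylphenyl replaced a two-ring group and the reading rose modestly. For the measured compounds named here, no measured step replaces the 4-methylphenyl itself with a smaller five-membered ring, so the direction for compound 4 cannot be read directly from the data. Since the smaller single-ring group did well in compound 3, and the thiophen-2-yl is also a single ring, the expectation for compound 4 is a step no larger than the scatter, or a small loss: a number 5 percentage points lower from compound 3 to compound 4 (within the scatter). Compound 4 is therefore estimated at 25%, within a range of 5% to 50%.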

Compound 4, a percentage reported as activity, at one concentration (the size of the read-out at that concentration, not a potency): 5%
The estimate for compound 4 lay 20 percentage points above the measured number; measured number inside the range.
By their numbers in this assay, from the lowest: compounds 1, 2 and 4 (each within the scatter of the next); then compound 3.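

In this assay, the result shows that being a single ring is not enough at this saturated ring carbon: replacing 4-methylphenyl with thiophen-2-yl gives a number 25 percentage points lower from compound 3 to compound 4 (beyond the scatter) and removes most of the reading seen with compound 3. The thiophen-2-yl group also brings compound 4 level with the two compounds carrying two-ring groups, with a number 3 percentage points higher from compound 2 to compound 4 (within the scatter) against the 2-hydroxynaphthalen-1-yl compound and a number 5 percentage points higher from compound 1 to compound 4 (within the scatter) against the 2-methoxynaphthalen-1-yl compound, so among these four compounds only the 4-methylphenyl group stands apart. No supporting information is available to explain why the reading changes with this swap.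

From the compounds shown here alone, it remains open whether the reading of compound 3 depends on the methyl group or on the six-membered aromatic ring itself, which a plain phenyl or a 4-chlorophenyl group at the same carbon would help to separate. A furan-2-yl or pyridin-3-yl group would likewise show whether the low reading of compound 4 belongs to five-membered rings in general, to the sulfur atom, or to any ring containing a hetero atom.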